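This account rests on a few compounds, and the source may have more. Where it says the series, first, only, none or still open, it means among the compounds named here.

Compound 2, `COc1cccc(-c2nc(SCC(=O)c3sc(-c4ccccc4)nc3C)[nH]c(=O)c2C#N)c1`, stands highest of the three compounds measured in a functional assay on U-87MG ATCC cells for antiproliferative activity against U-87 MG (Homo sapiens), read by MTT assay, with a stated time of 48 h, tested at 50 uM; a lower number here means a stronger effect, a higher number a weaker effect of the compound at the concentration tested: compound 2 gives 80.3%. Its nearest neighbour is compound 1, `COc1ccc(-c2nc(SCC(=O)c3sc(-c4ccccc4)nc3C)[nH]c(=O)c2C#N)cc1`, for which compound 1 gives 52.1%, and the furthest is compound 3, `Cc1nc(-c2ccccc2)sc1C(=O)CSc1nc(-c2cccc(Cl)c2)c(C#N)c(=O)[nH]1`, for which compound 3 gives 50.6%. The measured steps all lie on the aryl group attached to the shared core: a number 28.2 percentage points higher from compound 1 to compound 2 (beyond the scatter), a number 29.7 percentage points lower from compound 2 to compound 3 (beyond the scatter) and a number 1.5 percentage points lower from compound 1 to compound 3 (within the scatter).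

Compound 4, `COc1cccc(-c2nc(SCC(=O)c3sc(-c4ccc(Cl)cc4)nc3C)[nH]c(=O)c2C#N)c1`, differs from compound 2 at another place, on the phenyl that hangs from the other end of the molecule: chloro in place of hydrogen on an aromatic carbon. Within the data shown here, none of the measured steps touches that phenyl, so none bears directly on this change; the two steps beyond the scatter were of modest size and concern a different ring. With no guidance for this position, no step beyond the scatter is expected in this assay from compound 2 to compound 4, and the value of compound 4 is expected to stay close to that of compound 2, which is estimated as a number 4.3 percentage points lower from compound 2 to compound 4 (within the scatter). The estimate for compound 4 is therefore 76%, expected to fall between 52% and 95%.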

Compound 4, a percentage reported as activity, at one concentration (the size of the read-out at that concentration, not a potency): 47.6%
The estimate for compound 4 lay 28.4 percentage points above the measured number; measured number outside the range, below it.
By their numbers in this assay, from the lowest: compounds 4, 3 and 1 (each within the scatter of the next); then compound 2.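

The phenyl at the far end of the molecule proved to be a position that matters: in this assay, replacing its hydrogen with chloro, which turns phenyl into 4-chlorophenyl, gives a number 32.7 percentage points lower from compound 2 to compound 4 (beyond the scatter). The earlier compounds shown here varied only the aryl group on the other side of the shared core, so they could not show this; the step is large, whereas the two earlier steps beyond the scatter, a number 28.2 percentage points higher from compound 1 to compound 2 (beyond the scatter) and a number 29.7 percentage points lower from compound 2 to compound 3 (beyond the scatter), were modest. A single chlorine atom on an aromatic carbon, placed para to a large group, is thus enough to produce a step beyond the scatter, though nothing available here accounts for why it does so.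

Going by these compounds, the step is known only with the 3-methoxyphenyl group of compound 2 on the other side, so it remains open whether the same change would give a comparable step with the 4-methoxyphenyl group of compound 1 or the 3-chlorophenyl group of compound 3. On these data alone, it is also open whether the effect is specific to chloro or would be shared by other groups at this place on the phenyl, such as fluoro, methoxy, an amine or a carboxylic acid.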